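Octylamino on the Carbonyl Carbon: an Expected Modest Gain

The source may hold more compounds than are shown below. What is called first, only, known or untested is meant among the compounds shown, and "the series" means these compounds.

Compound 1 `CCCC(=O)OCC1CN(C(=O)c2cc(OC)c(OC)c(OC)c2)CCN1C(=O)c1cc(OC)c(OC)c(OC)c1` gives 420 nM in a functional assay (Oryctolagus cuniculus) for inhibition of platelet-activating factor receptor (Cavia porcellus); a lower number here means a stronger inhibitor, a higher number a weaker inhibitor.
Compound 2 `COc1cc(C(=O)N2CCN(C(=O)c3cc(OC)c(OC)c(OC)c3)C(COC(=O)NC(C)(C)C)C2)cc(OC)c1OC` gives 130 nM in this assay.
Compound 3 `COc1cc(C(=O)N2CCN(C(=O)c3cc(OC)c(OC)c(OC)c3)C(COC(=O)NCCC(C)C)C2)cc(OC)c1OC` gives 140 nM in this assay.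

Compound 1 has the highest number of the three, so it is the weakest inhibitor among them. Compound 4 `CCCCCCCCNC(=O)OCC1CN(C(=O)c2cc(OC)c(OC)c(OC)c2)CCN1C(=O)c1cc(OC)c(OC)c(OC)c1` differs from it in one place: octylamino in place of propyl on a carbonyl carbon. Two measured steps make the same kind of change at the same carbonyl carbon, an amino group in place of propyl: a 3.2-fold lower number from compound 1 to compound 2 (0.51 log units; beyond the scatter) and a 3.0-fold lower number from compound 1 to compound 3 (0.48 log units; beyond the scatter). Both lowered the number modestly and by nearly the same amount, and the step of a 1.1-fold higher number from compound 2 to compound 3 (0.03 log units; within the scatter) shows that the choice between the two amino groups hardly mattered. Octylamino is longer than either, and no measurement shows whether that matters. Compound 4 is therefore expected to show a modest lowering, a 3.0-fold lower number from compound 1 to compound 4 (0.48 log units; beyond the scatter). Compound 4 is estimated at 140 nM, within 60 nM to 330 nM.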

Compound 4, half-maximal inhibitory concentration: 370 nM
For compound 4 the middle estimate is 2.6-fold (0.42 log units) below the measured one; measured number outside the range, above it.
By their numbers in this assay, from the lowest: compounds 2 and 3 (each within the scatter of the next); then compounds 4 and 1 (each within the scatter of the next).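

Replacing propyl with an amino group on this carbonyl carbon does not by itself lower the number: with octylamino there is a 1.1-fold lower number from compound 1 to compound 4 (0.06 log units; within the scatter) in this assay. The group on the nitrogen matters here, with octyl weaker than the smaller groups: a 2.6-fold higher number from compound 3 to compound 4 (0.42 log units; beyond the scatter) and a 2.8-fold higher number from compound 2 to compound 4 (0.45 log units; beyond the scatter) are both beyond the scatter. Nothing available explains this difference. Open, from the compounds shown here alone, is how the number changes with chain lengths between isopentyl and octyl, such as hexylamino. Also open, going by these compounds, is how a ring on that nitrogen, such as cyclohexyl, would compare.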